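From a Ring Amide to a Longer Chain

A few compounds are considered here, and "the series" means these few. Any claim that something is new, unique, unknown or untested is made for them only; others in the source may bear on it.

Measured so far in a functional assay on FaDu cells (Homo sapiens) for antiproliferative activity, read by sulforhodamine B assay, with a stated time of 48 h; on this read-out lower numbers stand for stronger inhibition and higher numbers for weaker inhibition:
- Compound 1 `CCCCN(C)C(=O)CCCOc1cc(OC)c(OC)c2oc(-c3ccc(OC)cc3)c(O)c(=O)c12`: > 40000 nM (a limit)
- Compound 2 `CCCCN(C)C(=O)CCCCOc1cc(OC)c(OC)c2oc(-c3ccc(OC)cc3)c(O)c(=O)c12`: 22000 nM
- Compound 3 `COc1ccc(-c2oc3c(OC)c(OC)cc(OCCCCC(=O)N4CCN(C)CC4)c3c(=O)c2O)cc1`: > 40000 nM (a limit)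

Compound 3 stands at the limit of > 40000 nM in this assay, at which 2 of the 3 values shown sit. Compound 4 `CCCCCN(C)C(=O)CCCCCOc1cc(OC)c(OC)c2oc(-c3ccc(OC)cc3)c(O)c(=O)c12` is still unmeasured, and its difference from compound 3 is (methyl(pentyl)carbamoyl)methyl in place of (4-methylpiperazin-1-yl)carbonyl on a saturated chain carbon, four bonds along the chain from an oxygen on an aromatic ring. Within the data shown here, two measured steps bear on this change. The chain grows in an at least 1.8-fold lower number from compound 1 to compound 2 (0.25 log units; that floor lies within the scatter), and the ring-bearing amide replaces the butyl(methyl)amino amide in an at least 1.8-fold higher number from compound 2 to compound 3 (0.25 log units; that floor lies within the scatter). Both are only floors within the scatter, yet both favour the ring-free, longer-chain side, so compound 2 at 22000 nM is the closest guide. A modest fall in the number is therefore expected in this assay, with the estimated step of an at least 3.6-fold lower number from compound 3 to compound 4 (0.56 log units; beyond the scatter). Compound 4 is estimated at 11000 nM, with an expected range from 3500 nM to 32000 nM.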

Compound 4, half-maximal inhibitory concentration: > 40000 nM
Compound 4: only a limit was reported; the forecaster's own chance of this, stated with the estimate: 20%; middle value at least 3.6-fold (0.56 log units) from the limit.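

Compound 4 gives only a limit, so an amide without a ring does not by itself secure a measured value: the limit of > 40000 nM in this assay, at which 3 of the 4 values shown sit.

Compared with compound 2, the only compound here with an exact value, the change gives an at least 1.8-fold higher number from compound 2 to compound 4 (0.25 log units; that floor lies within the scatter), so no real loss can be claimed. The steps from compounds 1 and 3 to compound 4 cannot be read, as both ends are limits.

From the compounds shown here alone, compound 4 differs from compound 2 in both its amide chain and its linker, so the effect of each remains open. A butyl(methyl) amide on the longer chain, or a carboxylic acid at the chain end, remains an open case.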